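The source may hold more compounds than are shown below. What is called first, only, known or untested is meant among the compounds shown, and "the series" means these compounds.

Compound 2 `O=S(=O)(Nc1ccc2oc(-c3ccccc3)nc2c1)c1cccc(O)c1` is known in an assay on isolated protein for inhibition of malate dehydrogenase, mitochondrial (Sus scrofa), with stated times of 45 min and 30 min (on this read-out higher numbers stand for weaker inhibition and lower numbers for stronger inhibition), only by a limit: compound 2 gives > 63000 nM. Compound 1 `O=S(=O)(Nc1ccc2oc(-c3ccccc3)nc2c1)c1cccc(Cl)c1` likewise stops at a limit in this assay, where compound 1 gives > 63000 nM. Among the measured compounds shown here, the one measured step, a step that the two limits leave unreadable from compound 1 to compound 2, is hydroxy in place of chloro on an aromatic carbon, and its size is not readable because of the limit of > 63000 nM in this assay, at which 2 of the 2 values shown sit. Compound 3 `O=S(=O)(Nc1ccc2oc(-c3ccccc3)nc2c1)c1cccs1` differs from compound 2 by thiophen-2-yl in place of 3-hydroxyphenyl on a sulfonyl sulfur. For the measured compounds named here, no measured step bears on this change, so no size or direction beyond the scatter can be expected in this assay. Compound 3 is therefore estimated at 100000 nM, with a range from 20000 nM to 500000 nM. The expected step is a step that the limit leaves unreadable from compound 2 to compound 3, most likely again only a limit.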

Compound 3, half-maximal inhibitory concentration: > 63000 nM
Compound 3: no number, only a limit; the forecaster's own chance of this, stated with the estimate: 85%; the middle value does not contradict the limit.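

No new step can be read from compound 2 to compound 3 or from compound 1 to compound 3, because all three compounds stop at the same limit: the limit of > 63000 nM in this assay, at which 3 of the 3 values shown sit.

The compounds shown leave open whether 3-chlorophenyl, 3-hydroxyphenyl and thiophen-2-yl on the sulfonyl sulfur differ at all in this assay.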